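The source may hold more compounds than are shown below. What is called first, only, known or untested is meant among the compounds shown, and "the series" means these compounds.

In a functional assay on MOLT-4 cells (Homo sapiens) for inhibition, read by sulforhodamine B assay, with a stated time of 48 h (a lower number here means a stronger inhibitor of growth, a higher number a weaker inhibitor of growth), compound 1 `O=C(Cc1csc2nc(-c3ccc(Br)cc3)cn12)N/N=C/c1ccccc1` gives 37200 nM and compound 2 `O=C(Cc1csc2nc(-c3ccc(Br)cc3)cn12)N/N=C/c1ccccc1O` gives 10700 nM, the lower of the two numbers. Compound 3 `O=C(Cc1csc2nc(-c3ccc(Br)cc3)cn12)N/N=C/c1ccc(O)cc1` carries 4-hydroxyphenyl in place of 2-hydroxyphenyl on a carbon with a double bond to nitrogen. Within the data shown here, only one measured step bears on this, a 3.5-fold lower number from compound 1 to compound 2 (0.54 log units; beyond the scatter), a modest one for hydroxy in place of hydrogen on an aromatic carbon. Among the measured compounds shown here, no measured step covers moving the hydroxy, so part of that gain is expected to remain, with the number drifting upward. The expected change is small, an estimated 1.5-fold higher number from compound 2 to compound 3 (0.17 log units; within the scatter). The expected value for compound 3 is 16000 nM, with an estimated range of 6500 nM to 38000 nM.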

Compound 3, concentration for total growth inhibition: 10000 nM
For compound 3 the middle estimate is 1.6-fold (0.20 log units) above the measured one; low and high end bracket the measured number.
By their numbers in this assay, from the lowest: compounds 3 and 2 (each within the scatter of the next); then compound 1.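

In this assay, 4-hydroxyphenyl in place of 2-hydroxyphenyl gives a 1.1-fold lower number from compound 2 to compound 3 (0.03 log units; within the scatter), so these two placements of the hydroxy cannot be told apart. The gain from hydroxy is therefore not confined to 2-hydroxyphenyl, with a 3.7-fold lower number from compound 1 to compound 3 (0.57 log units; beyond the scatter). No supporting measurement bears on this result.

On these data alone, whether a methoxy, an amine or a carboxylic acid in place of the hydroxy would keep this gain remains open. Also open, as far as these compounds go, is how changes to the shared core would affect the number.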